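The source may hold more compounds than are shown below. What is called first, only, known or untested is meant among the compounds shown, and "the series" means these compounds.

Measured so far in a toxicity assay on HepG2 cells (Homo sapiens) for inhibition, read by CellTiter-Glo, with a stated time of 48 h; on this read-out lower numbers stand for stronger inhibition and higher numbers for weaker inhibition:

- compound 1, `Cc1cc(C)cc(NC(=O)COc2cc(C)nc3ccc(OCc4ccccc4)cc23)c1`: > 100000 nM, a limit of the assay
- compound 2, `COc1ccc2nc(C)c(NC(=O)C(=O)Nc3cc(C)cc(C)c3)c(O)c2c1`: > 100000 nM, a limit of the assay
- compound 3, `COc1ccc2nc(C)cc(OCC(=O)Nc3ccccc3)c2c1`: 39800 nM

Going by the values given here, compound 3 holds a special place here: in this assay compound 3 is the only compound that gives an actual number, and that number itself points to rather weak inhibition of the liver cells. Among the compounds with values here, the other two results are the limit of > 100000 nM in this assay, at which 2 of the 3 values shown sit, so they tell only that those compounds are weaker than the assay can resolve, not how much weaker.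

The next compound, compound 4 with the structure `COc1ccc2nc(C)cc(OCC(=O)Nc3cc(F)cc(F)c3)c2c1`, has not yet been measured. It differs from compound 3 in a single place: 3,5-difluorophenyl in place of phenyl on an amide-type nitrogen. Within the data shown here, no pair of measured compounds shows what this particular change does in this assay, so there is no measured step to lean on. With the same core and only two fluorine atoms added to the ring on the amide nitrogen, the step from compound 3 to compound 4 is expected to be small, a 1.0-fold higher number from compound 3 to compound 4 (0.00 log units; within the scatter), likely none beyond the usual scatter in either direction. Compound 4 is therefore estimated at 40000 nM, with a plausible range from 15000 nM to 120000 nM.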

Compound 4, half-maximal inhibitory concentration: > 100000 nM
Compound 4: a limit, no number; the forecaster's own chance of this, stated with the estimate: 35%; middle value at least 2.5-fold (0.39 log units) from the limit.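

In this assay, the ring on the amide-type nitrogen proves able to change the read-out: 3,5-difluorophenyl in place of phenyl gives an at least 2.5-fold higher number from compound 3 to compound 4 (0.40 log units; beyond the scatter). This is the only measured step among the compounds shown, and it reveals that this one change, with the rest of the molecule untouched, is enough to carry compound 4 beyond the range the assay can resolve. The true size of the step stays unknown, because the read-out stops at a limit: the limit of > 100000 nM in this assay, at which 3 of the 4 values shown sit.

The compounds shown leave open whether a fluorophenyl group carrying just one fluorine atom would produce a similar shift, and whether a chlorophenyl or methoxyphenyl group would do the same. They also cannot tell what an amine or a carboxylic acid on this ring would do.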